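Adding a Second Fluorine to the Benzamide Ring

A few compounds are considered here, and "the series" means these few. Any claim that something is new, unique, unknown or untested is made for them only; others in the source may bear on it.

Three compounds have been measured in an in vitro functional assay on HEK293-A cells for positive allosteric modulation of metabotropic glutamate receptor 5 (Homo sapiens), read by fluorescence and calcium flux, with a stated time of 140 s; a higher number here means that more compound is needed for the effect, a lower number that less compound is needed:

Compound 1, `O=C(c1ccc(F)c(F)c1)N1CCCC[C@@H]1c1nc(-c2cccc(F)c2)no1`, gives 1400 nM.
Compound 2, `O=C(c1cccc(F)c1)N1CCCC[C@@H]1c1nc(-c2cccc(F)c2)no1`, gives 460 nM.
Compound 3, `O=C(c1ccc(F)cc1)N1CCCC1c1nc(-c2cccc(F)c2)no1`, gives 3600 nM.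

Compound 1 differs from compound 2 by fluoro in place of hydrogen on an aromatic carbon, and this change gave a 3.0-fold higher number from compound 2 to compound 1 (0.48 log units; beyond the scatter). The difference between the cores of compound 3 and compound 2 is not broken down here. Compound 4, `O=C(c1ccc(F)cc1F)N1CCCC1c1nc(-c2cccc(F)c2)no1`, has not yet been measured; it differs from compound 3 by fluoro in place of hydrogen on an aromatic carbon. For the measured compounds named here, this is the same kind of change as the one from compound 2 to compound 1, but the surroundings differ: here the new fluoro sits ortho to a large group and meta to a fluoro group, whereas before it sat ortho to a fluoro group and para to a large group. A comparable rise is expected, resting on a 3.0-fold higher number from compound 2 to compound 1 (0.48 log units; beyond the scatter), so compound 4 is estimated at 7500 nM, a step of a 2.1-fold higher number from compound 3 to compound 4 (0.32 log units; beyond the scatter) from compound 3, with a likely range of 2500 nM to 22000 nM.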

Compound 4, half-maximal effective concentration: 10000 nM
Estimate against measurement, compound 4: 1.3-fold (0.12 log units) below; the range from low to high includes it.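

In this assay the added fluoro gave a 2.8-fold higher number from compound 3 to compound 4 (0.44 log units; beyond the scatter) and so raised the number on this core as well. The earlier step on the other core gives a very similar result: the same change on two cores in this assay, a 3.0-fold higher number (0.48 log units; beyond the scatter) from compound 2 to compound 1 and a 2.8-fold higher number (0.44 log units; beyond the scatter) from compound 3 to compound 4, 1.1-fold (0.04 log units) apart, within the scatter of two such steps

So in these two pairs, the penalty of a second fluorine on the benzamide ring carried over from one core to the other, even with the new fluoro in a different place on the ring; two pairs show neither why this happens nor that it would hold on further cores.

Still open, as far as these compounds go, is whether a chlorine atom or a methyl group in place of that same hydrogen would raise the number as fluoro does. An amine or a methoxy group there might also behave quite differently.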